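Chlorophenyl isomers: from compound 2 to compound 3

A few compounds are considered here, and "the series" means these few. Any claim that something is new, unique, unknown or untested is made for them only; others in the source may bear on it.

- compound 1 `O=C1Nc2ccccc2/C1=C/c1ccc(-c2cn(-c3ccccc3Cl)nn2)cc1`: > 20000 nM
- compound 2 `O=C1Nc2ccccc2/C1=C/c1ccc(-c2cn(-c3cccc(Cl)c3)nn2)cc1`: > 20000 nM

In a functional assay on HT-29 cells (Homo sapiens) for inhibition, read by CCK-8 assay, with a stated time of 24 h (on this read-out higher numbers stand for weaker inhibition and lower numbers for stronger inhibition), compound 2 gives only a limit, > 20000 nM. Compound 1 is also a limit, > 20000 nM. Compound 3 `O=C1Nc2ccccc2/C1=C/c1ccc(-c2cn(-c3ccc(Cl)cc3)nn2)cc1` carries 4-chlorophenyl in place of 3-chlorophenyl on an aromatic nitrogen, with 4-chlorophenyl in place of 3-chlorophenyl on an aromatic nitrogen. Within the data shown here, the one bearing measurement is a step that the two limits leave unreadable from compound 1 to compound 2, so it gives no size or direction. The sole anchor is the limit of > 20000 nM in this assay, at which 2 of the 2 values shown sit, and no step beyond the scatter is expected. The expected change is a number no higher from compound 2 to compound 3 (the limit leaves the size open). For compound 3 the estimate is 20000 nM, with an expected range of 8000 nM to 50000 nM.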

Compound 3, half-maximal inhibitory concentration: 14000 nM
Beside the measured number, compound 3's estimate is 1.4-fold (0.15 log units) above it, within the range that was stated.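

With 4-chlorophenyl on the aromatic nitrogen, compound 3 alone among the three chlorophenyl isomers gives a number in this assay. The readable steps are an at least 1.4-fold lower number from compound 2 to compound 3 (0.15 log units; that floor lies within the scatter) and an at least 1.4-fold lower number from compound 1 to compound 3 (0.15 log units; that floor lies within the scatter), so neither shows a firm preference at this position. The rest of the series remains limits rather than numbers: the limit of > 20000 nM in this assay, at which 2 of the 3 values shown sit.

The step between compound 1 and compound 2 cannot be read. Going by these compounds, how an amine or a carboxylic acid in place of the chlorine of 4-chlorophenyl would read remains open.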